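The compounds below may be only part of what the source reports. "The series", "measured", "known", "first", "only" and "open" are said of these compounds alone.

Measured so far:
compound 1, `O=C1C(Nc2ccc(I)cc2)=CC(=O)c2c1nc1n2[C@H]2OC[C@@H](O)[C@H]2OC1`, 3890 nM;
compound 2, `O=C1C=C(NC2CCCCC2)C(=O)c2c1nc1n2[C@H]2OC[C@@H](O)[C@H]2OC1`, a limit only;
compound 3, `O=C1C=C(Nc2cccc(F)c2)C(=O)c2c1nc1n2[C@H]2OC[C@@H](O)[C@H]2OC1`, 5500 nM.

All three compounds share one core and differ only in the group attached to an amine nitrogen. In a functional assay on MCF7 cells (Homo sapiens) for inhibition, read by sulforhodamine B assay (a higher number here means a weaker inhibitor, a lower number a stronger inhibitor), compound 1 gives 3890 nM. Compound 3 gives 5500 nM, and the two numbers lie within the usual scatter of each other, so neither can be called the stronger. Compound 2 gives only a limit of the assay, > 8000 nM, not a number. Going by the values given here, the single step that can be traced between measured compounds is an at least 1.4-fold lower number from compound 2 to compound 3 (0.16 log units; that floor lies within the scatter): an aromatic ring on the amine nitrogen in place of a non-aromatic one brings the value from the limit to a number, though the floor of that step lies within the scatter, since one of the three values sits at the limit of > 8000 nM in this assay, at which 1 of the 3 values shown sits.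

Compound 4, `O=C1C(NC2CC2)=CC(=O)c2c1nc1n2[C@H]2OC[C@@H](O)[C@H]2OC1`, has not yet been measured in this assay. It differs from compound 1 in one place: cyclopropyl in place of 4-iodophenyl on an amine nitrogen. Among the compounds with values here, a non-aromatic ring thus replaces an aromatic one on the amine nitrogen, the reverse of the only measured step, which suggests a higher number, an expected step of a 2.3-fold higher number from compound 1 to compound 4 (0.36 log units; beyond the scatter). Compound 4 is therefore estimated at 9000 nM, with a range from 3500 nM to 25000 nM.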

Compound 4, half-maximal inhibitory concentration: > 16000 nM
Compound 4: a limit, no number (the forecaster's own chance of this, stated with the estimate: 55%); middle value at least 1.7-fold (0.24 log units) away from the limit.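

In this assay, going by these compounds alone, putting cyclopropyl in place of 4-iodophenyl on the amine nitrogen brings an at least 4.1-fold higher number from compound 1 to compound 4 (0.61 log units; beyond the scatter), so this is the first step whose floor clears the usual scatter. Within the data shown here, the only earlier step, an at least 1.4-fold lower number from compound 2 to compound 3 (0.16 log units; that floor lies within the scatter), could not show that the ring on this nitrogen matters, whereas this one shows that it does, and in both steps the compound with the non-aromatic ring stands at a limit. As far as these compounds go, the true size of the new step stays unknown because compound 4 gives a limit and not a number: the limit of > 16000 nM in this assay, at which 1 of the 4 values shown sits.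

This step removes the aromatic ring and the iodine together and also changes the ring size, so it cannot tell which of these differences counts. From the compounds shown here alone, whether plain phenyl, with no iodine, or a straight propyl chain on the same nitrogen would give a number in this assay remains open.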